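The compounds below may be only part of what the source reports. "The series", "measured", "known", "first", "only" and "open" are said of these compounds alone.

Measured so far in a functional assay on the whole organism for inhibition, with Rattus norvegicus as the target; on this read-out higher numbers stand for an effect only at larger amounts of compound and lower numbers for an effect already at smaller amounts:
compound 1 `CC1CC/C(=N\Nc2ccccc2F)c2ncc(C(=O)O)c(=O)n21`: 5 umol/kg
compound 2 `CC1CC/C(=N\Nc2ccc(F)cc2)c2ncc(C(=O)O)c(=O)n21`: 12.2 umol/kg
compound 3 `CC1CC/C(=N\Nc2ccc(Cl)cc2)c2ncc(C(=O)O)c(=O)n21`: 0.5 umol/kg

Compound 3 stands lowest of the three; its nearest neighbour is compound 1, a 10-fold lower number from compound 1 to compound 3 (1.00 log units; beyond the scatter), and furthest is compound 2, a 24-fold lower number from compound 2 to compound 3 (1.39 log units; beyond the scatter). Compound 4 `CC1CC/C(=N\Nc2cccc(Br)c2)c2ncc(C(=O)O)c(=O)n21` is not yet measured. Change from compound 3 to compound 4: 3-bromophenyl in place of 4-chlorophenyl on an amine nitrogen. Among the compounds with values here, two measured steps bear on it only in part. The halogen swap gave a 24-fold lower number from compound 2 to compound 3 (1.39 log units; beyond the scatter), showing this assay responds strongly to the halogen on the phenyl. Moving a fluoro between positions gave a 2.4-fold higher number from compound 1 to compound 2 (0.39 log units; beyond the scatter). Within the data shown here, no step covers bromo or the 3-position, so a modest rise is expected, a 3.0-fold higher number from compound 3 to compound 4 (0.48 log units; beyond the scatter), and compound 4 is estimated at 1.5 umol/kg with a range of 0.4 umol/kg to 6 umol/kg.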

Compound 4, dose for 50% inhibition: 0.4 umol/kg
The estimate for compound 4 lay 3.8-fold (0.57 log units) above the measured number, within the range that was stated.
By their numbers in this assay, from the lowest: compounds 4 and 3 (each within the scatter of the next); then compound 1; then compound 2.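

In this assay, 3-bromophenyl on the amine nitrogen cannot be told apart from 4-chlorophenyl (a 1.3-fold lower number from compound 3 to compound 4 (0.10 log units; within the scatter)), so a low number here is not confined to 4-chlorophenyl. Both fluorophenyl compounds stay clearly separated from this level (a 31-fold lower number from compound 2 to compound 4 (1.48 log units; beyond the scatter); a 13-fold lower number from compound 1 to compound 4 (1.10 log units; beyond the scatter)). No measured evidence available here accounts for that separation.

On these data alone, because halogen and position change together between compound 3 and compound 4, their separate contributions remain open. 4-Bromophenyl and 3-chlorophenyl would separate them, while methoxy or trifluoromethyl on the phenyl would test whether a halogen is needed at all.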